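The compounds below may be only part of what the source reports. "The series", "measured", "known", "first", "only" and "open" are said of these compounds alone.

- compound 1 (`COc1cc(O)cc(O)c1C(=O)/C=C/c1ccc(F)cc1`) 28800 nM
- compound 2 (`COc1ccc(/C=C/C(=O)c2c(O)cc(O)cc2OC)cc1`) 166000 nM

Going by the values given here, in a toxicity assay on cells (Macrophage, Mus musculus, strain BALB/c) for cytotoxicity, read by MTT assay (a higher number here means a weaker inhibitor, a lower number a stronger inhibitor), compound 1 gives 28800 nM and so holds the lower of the two numbers so far. Compound 3 (`COc1cc(O)cc(O)c1C(=O)/C=C/Cc1ccccc1`) keeps the core of compound 1 and differs from it in one place (benzyl in place of 4-fluorophenyl on a double-bonded chain carbon bound to a double-bonded chain carbon): benzyl in place of 4-fluorophenyl on a double-bonded chain carbon bound to a double-bonded chain carbon.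

Among the compounds with values here, no measured compound carries benzyl, so the guide here is loose. Within the data shown here, the one measured step that bears on this is a different swap, methoxy in place of fluoro on an aromatic carbon (a 5.8-fold higher number from compound 1 to compound 2 (0.76 log units; beyond the scatter)), and like the new change it leaves the core untouched and removes the fluorine. The size of that single step (a 5.8-fold higher number from compound 1 to compound 2 (0.76 log units; beyond the scatter)) points to a modest move toward a higher number in this assay rather than a large one. The step expected is a 1.9-fold higher number from compound 1 to compound 3 (0.28 log units; within the scatter) by this estimate. For compound 3 the estimated value is 55000 nM (expected range 17000 nM to 170000 nM).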

Compound 3, half-maximal inhibitory concentration: 27000 nM
For compound 3 the middle estimate is 2.0-fold (0.31 log units) above the measured one; the range from low to high includes it.
By their numbers in this assay, from the lowest: compounds 3 and 1 (each within the scatter of the next); then compound 2.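

In this assay, benzyl in place of 4-fluorophenyl on a double-bonded chain carbon bound to a double-bonded chain carbon gives a 1.1-fold lower number from compound 1 to compound 3 (0.03 log units; within the scatter) and so leaves the two compounds indistinguishable in this cytotoxicity test. The earlier swap of methoxy for fluoro gave a 5.8-fold higher number from compound 1 to compound 2 (0.76 log units; beyond the scatter) and showed that a change on the aromatic ring can move the number beyond the scatter, whereas this result shows that the fluorine-bearing group can give way to benzyl, which also holds one six-membered aromatic ring of carbon only, with no shift that can be read. Nothing available here explains why this swap leaves the number in place.

The compounds shown leave open whether this chain position would stay as tolerant with a group that has no aromatic ring, such as an amine, a carboxylic acid or a longer carbon chain. They also leave open whether a methoxy group on the ring of the benzyl group would raise the number as it did on the 4-fluorophenyl ring's carbon in place of fluoro.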